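Aryl swap in the series: compound 2 to compound 3

The source may report more compounds than this note shows. Statements on the series, on what has been measured and on what is new or still open speak of the compounds shown alone.

Among the measured compounds shown here, compound 2 `O=C1C(O)=C(C(c2ccc(F)cc2)c2c[nH]c3ccccc23)C(=O)c2ccccc21` gives 65200 nM in a toxicity assay (Homo sapiens) for cytotoxicity, read by MTT assay, with a stated time of 48 h (a lower number here means a stronger inhibitor, a higher number a weaker inhibitor), and is the only compound here with a number rather than a limit. Compound 1 `COc1ccccc1C(C1=C(O)C(=O)c2ccccc2C1=O)c1c[nH]c2ccccc12` gives > 200000 nM in this assay, which is a limit. For the measured compounds named here, the one measured step, an at least 3.0-fold lower number from compound 1 to compound 2 (0.48 log units; beyond the scatter), can only be bounded, since the sole evidence on it is the limit of > 200000 nM in this assay, at which 1 of the 2 values shown sits. Compound 3 `COc1ccc(C(C2=C(O)C(=O)c3ccccc3C2=O)c2c[nH]c3ccccc23)cc1Br` differs from compound 2 by 3-bromo-4-methoxyphenyl in place of 4-fluorophenyl on a saturated chain carbon bound to an aromatic carbon and a double-bonded ring carbon. Going by the values given here, no measured step covers this change directly; the single step from compound 1 to compound 2 shows only that replacing a methoxy-bearing aryl by a fluorophenyl lowered the number to an unknown extent. Returning a methoxy group, now accompanied by a bromine, is therefore expected to move the number back up, by a 1.4-fold higher number from compound 2 to compound 3 (0.14 log units; within the scatter), with a real chance that only a limit is reported. Compound 3 is estimated at 90000 nM, within 30000 nM to 200000 nM.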

Compound 3, half-maximal inhibitory concentration: 25200 nM
For compound 3 the middle estimate is 3.6-fold (0.55 log units) above the measured one, and the stated range ends above it.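

Among the compounds shown here, with 3-bromo-4-methoxyphenyl in place of 4-fluorophenyl on the saturated chain carbon, this assay gives a 2.6-fold lower number from compound 2 to compound 3 (0.41 log units; beyond the scatter) and this is the only step here read between two numbers rather than against a limit. A methoxy-bearing aryl group therefore does not by itself keep the number high: compound 1 and compound 3 both carry one, yet they lie on opposite sides of compound 2. The change from 2-methoxyphenyl gives an at least 7.9-fold lower number from compound 1 to compound 3 (0.89 log units; beyond the scatter) and its size remains only a bound: the limit of > 200000 nM in this assay, at which 1 of the 3 values shown sits.

The bromine and the methoxy group enter together in compound 3, so their separate shares in the step stay unread, and a 3-bromophenyl or 4-methoxyphenyl group would separate them. Going by these compounds, how an amine or a carboxylic acid on this aryl ring would read in this assay also stays open.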